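This account rests on a few compounds, and the source may have more. Where it says the series, first, only, none or still open, it means among the compounds named here.

Compound 3 `COc1ccc(C(=O)c2cc(OC)c(OC)c(OC)c2)cc1NC(=O)/C=C/c1ccc(F)cc1` is the compound with the lowest number among the three measured in a functional assay on ME-180 cells (Homo sapiens) for cytotoxicity, read by MTT assay, with a stated time of 72 h (on this read-out higher numbers stand for weaker inhibition and lower numbers for stronger inhibition), at 300 nM. Compound 1 `COc1ccc(C(=O)c2cc(OC)c(OC)c(OC)c2)cc1NC(=O)/C=C/c1ccc(OC)c(OC)c1` gives 8900 nM, and compound 2 `C#CCOc1cccc(/C=C/C(=O)Nc2cc(C(=O)c3cc(OC)c(OC)c(OC)c3)ccc2OC)c1` gives 15300 nM. The steps to compound 3 are large: a 30-fold lower number from compound 1 to compound 3 (1.47 log units; beyond the scatter) and a 51-fold lower number from compound 2 to compound 3 (1.71 log units; beyond the scatter), whereas a 1.7-fold higher number from compound 1 to compound 2 (0.24 log units; within the scatter). Compound 4 `COc1ccc(C(=O)c2cc(OC)c(OC)c(OC)c2)cc1NC(=O)/C=C/c1ccc(N)cc1` differs from compound 3 by amino in place of fluoro on an aromatic carbon. Among the compounds with values here, no measured step bears directly on this change: the two steps that reach compound 3 exchange one whole aryl group for another, so the size of the step from 4-fluorophenyl to 4-aminophenyl cannot be read from the numbers in hand. The exchange of aryl groups has moved this series by large amounts, so a step beyond the scatter is possible in either direction. For compound 4 in this assay, the estimate is 600 nM, with a range of 100 nM to 4000 nM. The expected step is therefore a 2.0-fold higher number from compound 3 to compound 4 (0.30 log units; within the scatter), held loosely.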

Compound 4, half-maximal inhibitory concentration: 16000 nM
Beside the measured number, compound 4's estimate is 27-fold (1.43 log units) below it, outside the stated range (above it).
By their numbers in this assay, from the lowest: compound 3; then compounds 1, 2 and 4 (each within the scatter of the next).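

In this assay, within the data shown here, the exchange of amino for fluoro on an aromatic carbon para to a large group gives a 53-fold higher number from compound 3 to compound 4 (1.73 log units; beyond the scatter) on a change of a single heavy atom, whereas the earlier steps exchanged whole aryl groups. The 4-aminophenyl group gives a 1.8-fold higher number from compound 1 to compound 4 (0.25 log units; within the scatter) and a 1.0-fold higher number from compound 2 to compound 4 (0.02 log units; within the scatter) so that, of the four aryl groups shown, only the 4-fluorophenyl of compound 3 stands apart. Nothing at hand accounts for the size of the fluoro to amino step.

Open, from the compounds shown here alone, is whether chloro, bromo or a single methoxy on that same aromatic carbon would fall with compound 3 or with the other three compounds. Also open, going by these compounds, is whether a dimethylamino or acetamido group in place of the amino would move the number of compound 4.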